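The source may hold more compounds than are shown below. What is called first, only, known or untested is meant among the compounds shown, and "the series" means these compounds.

Compound 1 `COc1cc(-c2nn(-c3cccc(NC(=O)Nc4cc(C(F)(F)F)cc(C(F)(F)F)c4)c3)cc2-c2ccncc2)ccc1Cl`: 1550 nM
Compound 2 `O=C(Nc1cccc(-n2cc(-c3ccncc3)c(-c3ccc(Cl)c(O)c3)n2)c1)Nc1ccc(Cl)c(Cl)c1`: 1550 nM

In a functional assay on T47D cells (Homo sapiens) for inhibition, read by sulforhodamine B assay, with a stated time of 48 h (on this read-out lower numbers stand for stronger inhibition of growth and higher numbers for weaker inhibition of growth), compound 1 gives 1550 nM and compound 2 gives 1550 nM, so compound 1 stands level with compound 2, the two values lying within the usual scatter. Compound 3 `COc1cc(-c2nn(-c3cccc(NC(=O)Nc4cccc(C(F)(F)F)c4)c3)cc2-c2ccncc2)ccc1Cl` is compound 1 with hydrogen in place of trifluoromethyl on an aromatic carbon. Going by the values given here, no measured pair isolates this change, so its size cannot be read from the data. The step of a 1.6-fold higher number from compound 1 to compound 3 (0.21 log units; within the scatter) is expected: a modest weakening of growth inhibition that may only just exceed the scatter. Compound 3 is therefore estimated at 2500 nM, with a range from 1000 nM to 6500 nM.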

Compound 3, concentration for 50% growth inhibition: 1650 nM
Compound 3: the middle estimate sits 1.5-fold (0.18 log units) above what was measured, within the range that was stated.
By their numbers in this assay, from the lowest: compounds 1, 2 and 3 (each within the scatter of the next).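

Putting hydrogen in place of this trifluoromethyl gives a 1.1-fold higher number from compound 1 to compound 3 (0.03 log units; within the scatter) in this assay, so the two compounds stand level. At this position, the four heavy atoms of the trifluoromethyl group can go without a measurable loss of growth inhibition, at least while the other trifluoromethyl group remains. Nothing available explains this result. Still open, going by these compounds, is whether another group here, such as an amine or a carboxylic acid, would also stand level. On these data alone, it is also open whether hydrogen in place of the remaining trifluoromethyl would shift the value.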